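Methyl to Ethyl Beside the Pyridine in a Chloro Series

This account rests on a few compounds, and the source may have more. Where it says the series, first, only, none or still open, it means among the compounds named here.

Measured compounds:
compound 1 `Cc1ccc2c(c1)CC(CCN(C)C)=C2C(C)c1ccccn1`: 1450 nM
compound 2 `COc1ccc2c(c1)CC(CCN(C)C)=C2C(C)c1ccccn1`: 6030 nM
compound 3 `CC(C1=C(CCN(C)C)Cc2cc(Cl)ccc21)c1ccccn1`: 724 nM

In an assay on CHO-K1 cells for binding affinity to muscarinic acetylcholine receptor M5 (Homo sapiens) (a higher number here means a weaker inhibitor, a lower number a stronger inhibitor), compound 3 gives the lowest of the three numbers: the step of a 2.0-fold lower number from compound 1 to compound 3 (0.30 log units; within the scatter) lies within the scatter, while an 8.3-fold lower number from compound 2 to compound 3 (0.92 log units; beyond the scatter) and a 4.2-fold higher number from compound 1 to compound 2 (0.62 log units; beyond the scatter) are beyond it. Compound 4 `CCC(C1=C(CCN(C)C)Cc2cc(Cl)ccc21)c1ccccn1` differs from compound 3 by methyl in place of hydrogen on a saturated chain carbon, two bonds along the chain from an aromatic carbon and a double-bonded ring carbon. For the measured compounds named here, none of the measured steps touches this position; all three concern a group on an aromatic carbon and give no guide to the saturated chain. With nothing to support a shift either way, compound 4 is expected to stay close to compound 3, with a step of a 1.1-fold higher number from compound 3 to compound 4 (0.04 log units; within the scatter) that does not exceed the scatter. The estimate for compound 4 in this assay is 800 nM, within 300 nM to 2500 nM.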

Compound 4, inhibition constant: 776 nM
For compound 4 the middle estimate is 1.0-fold (0.01 log units) above the measured one; measured number inside the range.
By their numbers in this assay, from the lowest: compounds 3, 4 and 1 (each within the scatter of the next); then compound 2.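

Going from methyl to ethyl at this saturated chain carbon gives a 1.1-fold higher number from compound 3 to compound 4 (0.03 log units; within the scatter) in this assay, so this added methyl does not take the number outside the scatter in the chloro series. For the compounds shown here, this is the first measured change away from the aromatic carbon, where the earlier steps included two beyond the scatter. No evidence is available here on the reason for this result.

Still open, going by these compounds, is whether a longer chain such as propyl, or an amine on this carbon, would leave the number as little changed. Also open, on these data alone, is whether the same change would read alike with methyl or methoxy in place of the chloro.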